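Trifluoromethoxy on the N-phenyl of a quinoline ether

The source may hold more compounds than are shown below. What is called first, only, known or untested is meant among the compounds shown, and "the series" means these compounds.

Compound 1 `COc1cc2c(Oc3ccc(NC(=O)c4nn(-c5ccccc5)c(=O)cc4C)cc3F)ccnc2cc1OCCCN1CCCCC1`: 160 nM
Compound 2 `COc1cc2c(Oc3ccc(NC(=O)c4nn(-c5ccccc5)c(=O)cc4C)cc3F)ccnc2cc1OCCCN1CCN(C)CC1`: 270 nM

Of the compounds shown here, two have been measured in a functional assay on HT-29 cells (Homo sapiens) for inhibition, read by MTT assay, with a stated time of 72 h; on this read-out higher numbers stand for weaker inhibition and lower numbers for stronger inhibition. Compound 1 gives 160 nM and stands as the lower of the two numbers; compound 2 gives 270 nM, and the step of a 1.7-fold higher number from compound 1 to compound 2 (0.23 log units; within the scatter) lies within the scatter, so the two read as equivalent. That single step swaps the amine at the end of the chain and says nothing about the phenyl attached to the nitrogen of the shared core.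

Compound 3 `COc1cc2c(Oc3ccc(NC(=O)c4nn(-c5ccccc5OC(F)(F)F)c(=O)cc4C)cc3F)ccnc2cc1OCCCN1CCCCC1` is not yet measured. It differs from compound 1 only in that (trifluoromethoxy in place of hydrogen on an aromatic carbon). Within the data shown here, no measured pair bears on this change: the only step available, the one from compound 1 to compound 2, touches a distant part of the molecule. With nothing in the data to push the number either way, compound 3 is expected to come out close to compound 1, with the step of no change at the digits printed from compound 1 to compound 3 (within the scatter) expected to fall within the scatter. Compound 3 is therefore estimated at 160 nM in this assay, within a range of 60 nM to 450 nM.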

Compound 3, half-maximal inhibitory concentration: 190 nM
Compound 3: middle estimate off by 1.2-fold (0.07 log units), on the low side; low and high end bracket the measured number.
By their numbers in this assay, from the lowest: compounds 1, 3 and 2 (each within the scatter of the next).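

In this assay, the phenyl on the nitrogen of the shared core now has its first measured change: trifluoromethoxy in place of hydrogen on an aromatic carbon, ortho to a large group, gives a 1.2-fold higher number from compound 1 to compound 3 (0.07 log units; within the scatter). The exchange of phenyl for 2-(trifluoromethoxy)phenyl adds 5 heavy atoms and no ring, yet compound 3 and compound 1 read as equivalent, so at this position the group and hydrogen cannot be told apart in this read-out. Nothing measured alongside these numbers offers an explanation for this result.

As far as these compounds go, whether the same place gives an equivalent reading with a fluorine, a methoxy group, an amine or a carboxylic acid remains open, as does the reading of trifluoromethoxy on another carbon of that ring. From the compounds shown here alone, it is also open whether 2-(trifluoromethoxy)phenyl and the 4-methylpiperazin-1-yl chain end of compound 2 would read the same together in one molecule, as each change is seen here only on its own.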